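A few compounds are considered here, and "the series" means these few. Any claim that something is new, unique, unknown or untested is made for them only; others in the source may bear on it.

Measured compounds:

- compound 1, `COc1ccc2nc(C)cc(NCc3ccccc3)c2c1`: 28600 nM
- compound 2, `COc1cccc(CNc2cc(C)nc3ccc(OC)cc23)c1`: 12500 nM
- compound 3, `Cc1cc(NCc2ccc(F)cc2)c2ccccc2n1`: 20100 nM

All three were read in a functional assay on MCF-10A cells (Homo sapiens) for antiproliferative activity, with a stated time of 48 h; on this read-out higher numbers stand for an effect only at larger amounts of compound and lower numbers for an effect already at smaller amounts. Compound 1 and compound 2 differ by one change, (methoxy in place of hydrogen on an aromatic carbon); that step is a 2.3-fold lower number from compound 1 to compound 2 (0.36 log units; beyond the scatter). Compound 3 sits near compound 1 on this read-out; the difference between the two cores is not broken down here, and the gap between their numbers is within the scatter.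

Compound 4, `COc1ccc2c(NCc3ccc(F)cc3)cc(C)nc2c1`, is not yet measured. It differs from compound 3 by methoxy in place of hydrogen on an aromatic carbon. Among the compounds with values here, this is the same kind of change as the one from compound 1 to compound 2, but not the same: in compound 2 the methoxy enters on a six-membered aromatic ring of carbon only, meta to a large group, whereas in compound 4 it enters on a ring that is part of a fused or bridged system of two rings, meta to a fused ring and para to a fused ring.

Within the data shown here, the expectation rests on the one measured instance of this kind of change, the step of a 2.3-fold lower number from compound 1 to compound 2 (0.36 log units; beyond the scatter), tempered by the different surroundings of the place. The step from compound 3 to compound 4 is expected to be a 1.7-fold lower number from compound 3 to compound 4 (0.22 log units; within the scatter) in this assay. Compound 4 is therefore estimated at 12000 nM, with a likely span from 5000 nM to 30000 nM.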

Compound 4, half-maximal effective concentration: 15900 nM
For compound 4 the middle estimate is 1.3-fold (0.12 log units) below the measured one; low and high end bracket the measured number.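

In this assay, methoxy in place of hydrogen on an aromatic carbon gives a 1.3-fold lower number from compound 3 to compound 4 (0.10 log units; within the scatter), so on this core the change does not clearly separate the two compounds. Set beside the earlier step, the two cores cannot be told apart in their response to this change: the same change on two cores in this assay, a 2.3-fold lower number (0.36 log units; beyond the scatter) from compound 1 to compound 2 and a 1.3-fold lower number (0.10 log units; within the scatter) from compound 3 to compound 4, 1.8-fold (0.26 log units) apart, within the scatter of two such steps The data are therefore compatible with the change carrying over between these two cores, but two pairs do not establish this, particularly as only the first step lies beyond the scatter and the methoxy enters at a different kind of place in each pair.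

Going by these compounds, whether an amine, a hydroxyl or a longer alkoxy chain in place of the methoxy on the fused ring system would give a step beyond the scatter remains open. Also open, on these data alone, is whether the methoxy changes seen in these two pairs would add up if combined in one compound.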